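A few compounds are considered here, and "the series" means these few. Any claim that something is new, unique, unknown or untested is made for them only; others in the source may bear on it.

Compound 1 `O=c1c2ccccc2c(-c2cccnc2)nn1C1CCCC1` carries the shared core and in a functional assay (trachea) with Cavia porcellus as the target (a higher number here means a weaker inhibitor, a lower number a stronger inhibitor), compound 1 gives 2750 nM. Compound 2 `COCCn1nc(-c2cccnc2)c2ccccc2c1=O` gives 9330 nM in this assay, and compound 3 `CC(=O)OCCn1nc(-c2cccnc2)c2ccccc2c1=O` gives 9770 nM. Of these three numbers, compound 3 has the highest; compound 2 is nearest, and the two lie within the scatter of each other, while compound 1 is furthest, separated by a step beyond the scatter. The measured steps are a 3.4-fold higher number from compound 1 to compound 2 (0.53 log units; beyond the scatter) and a 3.6-fold higher number from compound 1 to compound 3 (0.55 log units; beyond the scatter), both modest and in the same direction, and a 1.0-fold higher number from compound 2 to compound 3 (0.02 log units; within the scatter), which lies within the scatter.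

Compound 4 `O=C(O)CCCn1nc(-c2cccnc2)c2ccccc2c1=O` has not yet been measured. It differs from compound 3 as follows: carboxymethyl in place of acetoxy on a saturated chain carbon, two bonds along the chain from an aromatic nitrogen. Among the measured compounds shown here, no measured pair exchanges an acetoxy for a carboxymethyl, so the known steps bear on it only indirectly. The steps from compound 1 to compound 2 and compound 3 show that replacing the cyclopentyl on the aromatic nitrogen with a chain shifts the number modestly upward, while a 1.0-fold higher number from compound 2 to compound 3 (0.02 log units; within the scatter) shows that exchanging one small group on that chain for another leaves the number within the scatter. The step to compound 4 is therefore expected to be small, a 1.2-fold higher number from compound 3 to compound 4 (0.09 log units; within the scatter), with a slight lean toward a higher number. Compound 4 is expected to give 12000 nM in this assay, within an estimated range from 4000 nM to 40000 nM.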

Compound 4, half-maximal inhibitory concentration: > 100000 nM
Compound 4: only a limit was reported; the forecaster's own chance of this, stated with the estimate: 15%; middle value at least 8.3-fold (0.92 log units) from the limit.
By their numbers in this assay, from the lowest: compound 1; then compounds 2 and 3 (each within the scatter of the next). At a limit, above all of these: compound 4.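

Among compounds 1 to 3, exchanging one end group on the chain for another left this assay within the scatter, but the end of this chain proves far from indifferent once the carboxylic acid enters, with an at least 10-fold higher number from compound 3 to compound 4 (1.01 log units; beyond the scatter) and, for carboxymethyl in place of methoxy, an at least 10-fold higher number from compound 2 to compound 4 (1.03 log units; beyond the scatter). For compound 4 the reading is a limit of the assay and not a number: the limit of > 100000 nM in this assay, at which 1 of the 4 values shown sits. Acetoxy and carboxymethyl hold the same atoms joined differently, with the entering group carrying a hydrogen-bond donor that the leaving group lacks, so so large a step shows that this position responds to how those atoms are arranged rather than to their number, and the full change from the cyclopentyl, an at least 36-fold higher number from compound 1 to compound 4 (1.56 log units; beyond the scatter), is much larger than the modest steps to the neutral chains.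

The compounds shown cannot separate the carboxylic acid itself from the extra chain length, so it remains open how a methyl ester or an amide on the same chain would read, or a carboxylic acid on a shorter chain. Nor do they show how far the true value of compound 4 lies past its limit.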